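Compound 3 to compound 4: furan-3-yl for phenyl

A few compounds are considered here, and "the series" means these few. Any claim that something is new, unique, unknown or untested is made for them only; others in the source may bear on it.

In a functional assay for inhibition, with Homo sapiens as the target (on this read-out higher numbers stand for weaker inhibition and lower numbers for stronger inhibition), compound 1 `COCc1cc(-c2ccccc2)c2ccc(OCc3cccc(C4(O)CCOCC4)c3)cc2c1` gives 4 nM, compound 2 `CC(=O)c1cc(-c2ccccc2)c2ccc(OCc3cccc(C4(O)CCOCC4)c3)cc2c1` gives 2 nM and compound 3 `N#Cc1cc(-c2ccccc2)c2ccc(OCc3cccc(C4(O)CCOCC4)c3)cc2c1` gives 3 nM. Compound 3 therefore stands among the three values without separation from either neighbour. The measured steps are a 1.3-fold lower number from compound 1 to compound 3 (0.12 log units; within the scatter), a 1.5-fold higher number from compound 2 to compound 3 (0.18 log units; within the scatter) and a 2.0-fold lower number from compound 1 to compound 2 (0.30 log units; within the scatter), so the three cannot be ranked.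

The next change leaves the cyano group in place and alters the other aromatic substituent. Compound 4 `N#Cc1cc(-c2ccoc2)c2ccc(OCc3cccc(C4(O)CCOCC4)c3)cc2c1` carries furan-3-yl in place of phenyl on an aromatic carbon, ortho to a fused ring: furan-3-yl in place of phenyl on an aromatic carbon.

For the measured compounds named here, no measured step touches the phenyl group, so the series holds no direct evidence for this swap. All three steps concern the group replaced at the carbon now bearing cyano, and they show only that acetyl, cyano and methoxymethyl give values within the scatter. They bear on the swap indirectly, as a measure of how little the read-out has moved so far. No shift beyond the scatter is expected, and no direction is firmly favoured. The expected change is a 1.3-fold higher number from compound 3 to compound 4 (0.12 log units; within the scatter). The range is kept wide, as this substituent has not been varied before. In this assay the estimate for compound 4 is 4 nM, with an expected range of 1.5 nM to 12 nM.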

Compound 4, half-maximal inhibitory concentration: 2 nM
Beside the measured number, compound 4's estimate is 2.0-fold (0.30 log units) above it; measured number inside the range.
By their numbers in this assay, from the lowest: compounds 2, 4, 3 and 1 (each within the scatter of the next).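

In this assay, furan-3-yl in place of phenyl on the aromatic carbon ortho to a fused ring gives a 1.5-fold lower number from compound 3 to compound 4 (0.18 log units; within the scatter) and so leaves the read-out within the scatter. For the compounds shown here, this is the first variation at this position: the earlier steps concerned only the carbon now bearing cyano, whereas here a five-membered aromatic ring with 1 hetero atom replaces a six-membered aromatic ring of carbon only, with 5 heavy atoms for 6 and 1 hydrogen-bond acceptor for 0, and no separation appears. Nothing at hand explains why the read-out holds across this swap.

The compounds shown place only these two aromatic rings at this carbon, so it remains open whether an amine, a carboxylic acid, a longer chain or a saturated ring such as piperidine would be accepted there. Furan-3-yl also appears only alongside cyano, which leaves open whether the same swap would read alike with acetyl or methoxymethyl at the other position.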